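The compounds below may be only part of what the source reports. "The series", "measured", "known", "first", "only" and "open" are said of these compounds alone.

Measured so far in the assay of bombesin receptor subtype-3 agonism:

compound 1, `CCC(C)(C)Cc1c[nH]c(CCc2ccc(-c3ccncc3)cc2)n1`: 305 nM
compound 2, `CCC(C)(C)Cc1c[nH]c(CCc2ccc(-n3cccn3)cc2)n1`: 135 nM
compound 3, `CCC(C)(C)Cc1c[nH]c(CCc2ccc(-n3cncn3)cc2)n1`: 570 nM

In a functional assay on HEK293 cells for agonist activity at Bombesin receptor subtype-3 (Homo sapiens), read by luminescence and calcium flux, with a stated time of 10 min (on this read-out lower numbers stand for an effect already at smaller amounts and higher numbers for an effect only at larger amounts of compound), compound 3 carries the highest number of the three; the step of a 1.9-fold higher number from compound 1 to compound 3 (0.27 log units; within the scatter) lies within the scatter, while a 4.2-fold higher number from compound 2 to compound 3 (0.63 log units; beyond the scatter) lies beyond it. Compound 4, `CCC(C)(C)Cc1c[nH]c(CCc2ccc(N3CCCCC3)cc2)n1`, differs from compound 3 by piperidin-1-yl in place of 1H-1,2,4-triazol-1-yl on an aromatic carbon. Within the data shown here, none of the measured steps involves a non-aromatic ring at this position; a 2.3-fold lower number from compound 1 to compound 2 (0.35 log units; beyond the scatter), a 1.9-fold higher number from compound 1 to compound 3 (0.27 log units; within the scatter) and a 4.2-fold higher number from compound 2 to compound 3 (0.63 log units; beyond the scatter) only exchange one aromatic ring for another and stay modest in size. A modest step to a lower number, a 2.3-fold lower number from compound 3 to compound 4 (0.36 log units; beyond the scatter), is therefore expected, with wide uncertainty. For compound 4 the estimate is 250 nM, within a range of 60 nM to 1000 nM.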

Compound 4, half-maximal effective concentration: 171 nM
Estimate against measurement, compound 4: 1.5-fold (0.16 log units) above; measured number inside the range.
By their numbers in this assay, from the lowest: compounds 2, 4, 1 and 3 (each within the scatter of the next, the first and the last beyond it).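

In this assay a non-aromatic ring proves compatible with this position on the aromatic carbon, which the aromatic replacements could not show: piperidin-1-yl in place of 1H-1,2,4-triazol-1-yl gives a 3.3-fold lower number from compound 3 to compound 4 (0.52 log units; beyond the scatter) and stays level with the two other aromatic groups, with a 1.3-fold higher number from compound 2 to compound 4 (0.10 log units; within the scatter) and a 1.8-fold lower number from compound 1 to compound 4 (0.25 log units; within the scatter) both within the scatter. No evidence is at hand that would explain these steps.

The compounds shown leave open whether a morpholin-4-yl ring or an open-chain dimethylamino group would be tolerated equally here. They also leave open how a carboxylic acid at this position would fare.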